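This account rests on a few compounds, and the source may have more. Where it says the series, first, only, none or still open, it means among the compounds named here.

Working notes on the series, all read in a functional assay on MDA-MB-231 cells (Homo sapiens) for cytotoxicity, read by MTT assay, with a stated time of 24 h; on this read-out lower numbers stand for stronger inhibition and higher numbers for weaker inhibition. Compound 1 `COc1ccc2c(c1)cc(-c1cc(OC)c(OC)c(OC)c1)n2Cc1ccc(OCc2ccccc2)cc1` gives > 30000 nM as a limit of the assay and not a number. Compound 2 `COc1ccc2c(c1)c(Cc1ccccc1)c(-c1cc(OC)c(OC)c(OC)c1)n2Cc1ccccc1` gives > 30000 nM as a limit too. Compound 3 `COc1ccc2c(c1)c(Cc1ccc(O)cc1)c(-c1cc(OC)c(OC)c(OC)c1)n2Cc1ccc(O)cc1` gives > 30000 nM as a limit too. Compound 1 therefore stands with compound 2 and compound 3 at the limit of > 30000 nM in this assay, at which 3 of the 3 values shown sit, and no measured number exists yet for any of them.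

Compound 4 `CCOCC(=O)Oc1ccc(Cn2c(-c3cc(OC)c(OC)c(OC)c3)cc3cc(OC)ccc32)cc1` keeps the core of compound 1 and has (ethoxymethyl)carbonyl in place of benzyl on an oxygen on an aromatic ring. No measured step sizes this change, and in this assay no shift beyond the scatter is expected. The expected step of a number no higher from compound 1 to compound 4 (the limit leaves the size open) stays small. This expectation rests on the limit of > 30000 nM in this assay, at which 3 of the 3 values shown sit, and another limit is the likeliest report for compound 4. For compound 4 the estimated value is 30000 nM (expected range 10000 nM to 60000 nM).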

Compound 4, half-maximal inhibitory concentration: > 30000 nM
Compound 4: no number, only a limit; the forecaster's own chance of this, stated with the estimate: 65%; the middle value lies on the limit itself.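

In this assay, among these compounds, compound 4 gives only a limit of the assay, as compound 1 does, so no step between compound 1 and compound 4 can be read. The compounds shown leave open whether any change on the shared core brings a measured number in this assay at all.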